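Swapping 2-methoxybenzyl for 4-isopropylphenyl

The source may hold more compounds than are shown below. What is called first, only, known or untested is meant among the compounds shown, and "the series" means these compounds.

Values in a functional assay on MCF7 cells (Homo sapiens) for inhibition, read by CCK-8 assay, with a stated time of 48 h (a higher number here means a weaker inhibitor of growth, a lower number a stronger inhibitor of growth), follow
Compound 1 (`Cc1ccccc1Nc1nc(Nc2ccc(N3CCN(C)CC3)cn2)ncc1Cl`) gives (5210 nM)
Compound 2 (`CN1CCN(c2ccc(Nc3ncc(Cl)c(NCc4ccc(F)cc4)n3)nc2)CC1`) gives (19300 nM)
Compound 3 (`COc1ccccc1CNc1nc(Nc2ccc(N3CCN(C)CC3)cn2)ncc1Cl`) gives (> 100000 nM) as a limit

Compound 3 stands at a limit (> 100000 nM) and not at a number. Compound 4 (`CC(C)c1ccc(Nc2nc(Nc3ccc(N4CCN(C)CC4)cn3)ncc2Cl)cc1`) carries 4-isopropylphenyl in place of 2-methoxybenzyl on a nitrogen on an aromatic ring. The nearest measured comparison is 2-methylphenyl on that nitrogen in compound 1. Benzyl groups there gave higher numbers, a modest step (a 3.7-fold higher number from compound 1 to compound 2 (0.57 log units; beyond the scatter)) and a large one (an at least 19-fold higher number from compound 1 to compound 3 (1.28 log units; beyond the scatter)), both beyond the scatter. A large downward step in this assay is therefore expected, returning near compound 1 (5210 nM). The expected change is (an at least 15-fold lower number from compound 3 to compound 4 (1.18 log units; beyond the scatter)). Compound 4 is estimated at (6500 nM), with an expected range from (1800 nM) to (25000 nM).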

Compound 4, concentration for 50% growth inhibition: 1880 nM
The estimate for compound 4 lay 3.5-fold (0.54 log units) above the measured number, within the range that was stated.
By their numbers in this assay, from the lowest: compound 4; then compound 1; then compound 2. At a limit, above all of these: compound 3.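

In this assay, compound 4 is the strongest inhibitor of the four, with 4-isopropylphenyl on this nitrogen giving a 2.8-fold lower number from compound 1 to compound 4 (0.44 log units; beyond the scatter) and a 10-fold lower number from compound 2 to compound 4 (1.01 log units; beyond the scatter). Compound 3 stands at a limit, so its step is only a bound: an at least 53-fold lower number from compound 3 to compound 4 (1.72 log units; beyond the scatter). The phenyl compounds, compound 1 and compound 4, now both give lower numbers than the benzyl compounds, compound 2 and compound 3.

Whether the isopropyl group itself accounts for the lower number stays open. So does how an amine or a carboxylic acid on that phenyl ring would fare in this assay.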